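The source may hold more compounds than are shown below. What is called first, only, known or untested is meant among the compounds shown, and "the series" means these compounds.

Measured so far in a functional assay on HL-60 cells (Homo sapiens) for inhibition, read by CCK-8 assay, with a stated time of 48 h; a higher number here means a weaker inhibitor, a lower number a stronger inhibitor:
compound 1 `O=[N+]([O-])c1ccc(NC(=S)N2CCN(S(=O)(=O)c3sccc3-c3ccccc3Oc3ccc(O)c(O)c3)CC2)cc1` gives 5300 nM
compound 2 `O=S(=O)(NCCNC(=S)Nc1cc(C(F)(F)F)cc(C(F)(F)F)c1)c1ccc(-c2ccccc2OCc2ccccc2)s1` gives 2100 nM

Compound 2 has the lowest of the two numbers in this assay; its nearest neighbour is compound 1, whose number is higher by a margin beyond the usual scatter. Among the measured compounds shown here, the two measured compounds differ in several places at once, so no single step between them can be read from the data.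

Compound 3 `O=S(=O)(NCCNC(=S)Nc1cc(C(F)(F)F)cc(C(F)(F)F)c1)c1ccc(-c2ccccc2O[C@H]2CC[C@@H](O)CC2)s1` has not yet been measured. It derives from compound 2 by one change, (4-hydroxycyclohexyl in place of benzyl on an oxygen on an aromatic ring). For the measured compounds named here, no measured pair shows this same change, so the expectation rests on compound 2 alone and is held loosely. The step expected is a 1.7-fold higher number from compound 2 to compound 3 (0.22 log units; within the scatter), a modest move towards a higher number, with wide uncertainty on either side. Compound 3 is therefore expected to give 3500 nM in this assay, with a likely range from 900 nM to 14000 nM.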

Compound 3, half-maximal inhibitory concentration: 2600 nM
For compound 3 the middle estimate is 1.3-fold (0.13 log units) above the measured one; low and high end bracket the measured number.
By their numbers in this assay, from the lowest: compounds 2 and 3 (each within the scatter of the next); then compound 1.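

In this assay, the benzyl on an oxygen on an aromatic ring of compound 2 gives way to 4-hydroxycyclohexyl without a change that can be told from scatter: the step is a 1.2-fold higher number from compound 2 to compound 3 (0.09 log units; within the scatter). At this position, then, a six-membered aromatic ring of carbon only can be exchanged for a non-aromatic one with the same number of heavy atoms, bringing in a hydrogen-bond donor, a hydrogen-bond acceptor and two defined stereocentres, and the reading holds. No measurement at hand accounts for why these two groups read alike.

The compounds shown leave open whether a plain cyclohexyl, or a cyclohexyl carrying an amine or a carboxylic acid in place of the hydroxyl, would read the same. They also leave open how the other stereoisomer of the 4-hydroxycyclohexyl group, or a longer chain on this oxygen, would read.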